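Swapping an aromatic ring for a small heterocycle

The compounds below may be only part of what the source reports. "The series", "measured", "known", "first", "only" and "open" are said of these compounds alone.

Of the compounds shown here, two sharing one core have been measured in a physicochemical assay for solubility, in phosphate buffer, measured as kinetic solubility, with a stated time of 1 h, at pH 7.4; on this read-out higher numbers stand for higher solubility and lower numbers for lower solubility. Compound 1 `COc1ccc2nc(C)cc(OCC(=O)Nc3cc(C)ccc3OC)c2c1` gives 9500 nM, the higher of the two numbers. Compound 2 `COc1ccc2nc(C)cc(OCC(=O)Nc3cc(OC)c(Cl)cc3OC)c2c1` gives 3000 nM, and the gap between the two values lies beyond the scatter of this assay, so compound 1 stands clearly above compound 2 on the numbers shown. For the measured compounds named here, no step between measured compounds that differ in only one place is available, so the measured pair serves only as a reference for where this series sits.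

Compound 3 `COc1ccc2nc(C)cc(OCC(=O)NC3CONC3=O)c2c1` has not yet been measured. It differs from compound 1 in one place, (a group of 6 heavy atoms (3 carbon, 1 nitrogen, 2 oxygen; one five-membered non-aromatic ring with 2 hetero atoms) in place of a group of 9 heavy atoms (8 carbon, 1 oxygen; one six-membered aromatic ring of carbon only), on an amide-type nitrogen). The group that leaves carries the aromatic ring and the methoxy group; the group that enters is a five-membered non-aromatic ring with 2 hetero atoms bearing 1 hydrogen-bond donor and 2 hydrogen-bond acceptors.

With no measured step of this kind in hand, the direction can only be an expectation. An upward step is expected, namely a 4.2-fold higher number from compound 1 to compound 3 (0.62 log units; beyond the scatter), beyond the scatter. Compound 3 is therefore estimated to reach 40000 nM, within a range from 12000 nM to 130000 nM.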

Compound 3, solubility: >= 166000 nM
Compound 3 was reported as a limit; the forecaster's own chance of this, stated with the estimate: 15%; at least 4.1-fold (0.61 log units) between middle value and limit.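

On the amide-type nitrogen, putting the five-membered non-aromatic ring with 2 hetero atoms in place of 2-methoxy-5-methylphenyl gives an at least 17-fold higher number from compound 1 to compound 3 (1.24 log units; beyond the scatter) in this assay, the first measured step at this position among the compounds shown. Compounds 1 and 2 both carry a six-membered aromatic ring of carbon only on this nitrogen, so they could only hint at where the series sits, not at what a change of this group can do. The value of compound 3 is a limit of the assay and not a number, so the step shows a large rise whose true size stays unknown: the limit of >= 166000 nM in this assay, at which 1 of the 3 values shown sits.

This single change alters the ring type, the ring size and the count of hydrogen-bond donors all at once, and the compounds shown cannot separate these from one another. Also open, on these data alone, is how a five-membered ring of carbon only, a piperidine amine or a group with a carboxylic acid on the same nitrogen would compare, and how compound 3 behaves on any read-out other than this one.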